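The source may hold more compounds than are shown below. What is called first, only, known or untested is meant among the compounds shown, and "the series" means these compounds.

Compound 1 `CNC(=O)c1cc(Oc2ccc(NS(=O)(=O)c3ccccc3)cc2)ccn1` gives in a functional assay on PLC-PRF-5 cells (Homo sapiens) for inhibition (on this read-out higher numbers stand for weaker inhibition and lower numbers for stronger inhibition), only the limit > 40000 nM.
Compound 2 `CNC(=O)c1cc(Oc2ccc(NS(=O)(=O)c3ccc(C(C)(C)C)cc3)cc2)ccn1` gives in this assay only the limit > 40000 nM.
Compound 3 `CNC(=O)c1cc(Oc2ccc(NS(=O)(=O)c3ccc4ccccc4c3)cc2)ccn1` gives in this assay only the limit > 40000 nM.

Compound 3 stands nowhere that can be located on a scale: its value is a limit of the assay, and the other two values shown are limits as well, as the limit of > 40000 nM in this assay, at which 3 of the 3 values shown sit, records. Compound 4 `CNC(=O)c1cc(Oc2ccc(NS(=O)(=O)c3ccccc3[N+](=O)[O-])cc2)ccn1` differs from it by 2-nitrophenyl in place of naphthalen-2-yl on a sulfonyl sulfur. Of the measured steps, a step that the two limits leave unreadable from compound 1 to compound 3 and a step that the two limits leave unreadable from compound 2 to compound 3 touch the same sulfonyl-bound group, while a step that the two limits leave unreadable from compound 1 to compound 2 changes a substituent on it; none of them can be read in size. Every value involved in them is a limit. For the measured compounds named here, no reading of a step therefore exists on which to build, and nothing in these numbers separates a change at the aryl group on the sulfonyl sulfur from no change at all. The only expectation one can form is that compound 4 is estimated to stay at the same limit as the three compounds before it, so its step that the limit leaves unreadable from compound 3 to compound 4 is expected to be unreadable as well. In this assay compound 4 is therefore expected to give about 60000 nM, within a range from 15000 nM to 250000 nM.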

Compound 4, half-maximal inhibitory concentration: > 40000 nM
Compound 4: only a limit was reported; the forecaster's own chance of this, stated with the estimate: 85%; the middle value does not contradict the limit.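

In this assay compound 4 gives > 40000 nM as a limit of the assay and not a number. For the compounds shown here, no step linking compound 4 with compound 1, compound 2 or compound 3 can be read in size, because all four compounds sit at one value: the limit of > 40000 nM in this assay, at which 4 of the 4 values shown sit. The compounds shown leave open how strongly any of them inhibits in this assay and whether changing the aryl group on the sulfonyl sulfur makes any difference.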